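The source may hold more compounds than are shown below. What is called first, only, known or untested is meant among the compounds shown, and "the series" means these compounds.

Values in a functional assay on NFS-60 cells (Mus musculus) for inhibition, with a stated time of 72 h; a lower number here means a stronger inhibitor of growth, a higher number a weaker inhibitor of growth:
- compound 1 `Nc1ncnc2c(C(=O)Nc3cccc4c3c(Br)nn4Cc3cccnc3)csc12`: 77 nM
- compound 2 `Nc1ncnc2c(C(=O)Nc3cccc4c3c(Br)nn4Cc3ccncc3)csc12`: 135 nM
- compound 3 `Cc1cccc(Cn2nc(Br)c3c(NC(=O)c4csc5c(N)ncnc45)cccc32)n1`: 27.5 nM

Compound 3 has the lowest of these three numbers, and its gaps to the other two lie beyond the scatter. Compound 4 `CCn1nc(Cn2nc(Br)c3c(NC(=O)c4csc5c(N)ncnc45)cccc32)cc1C(C)C` differs from it by 1-ethyl-5-isopropyl-1H-pyrazol-3-yl in place of 6-methylpyridin-2-yl on a saturated chain carbon bound to an aromatic nitrogen.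

All three measured steps are exchanges at this same place. The first, a 1.8-fold higher number from compound 1 to compound 2 (0.24 log units; within the scatter), does not separate the two compounds. The other two are a 2.8-fold lower number from compound 1 to compound 3 (0.45 log units; beyond the scatter) and a 4.9-fold lower number from compound 2 to compound 3 (0.69 log units; beyond the scatter). These steps show that changing the aromatic ring here has moved the number only modestly so far. Within the data shown here, none of the measured compounds carries a five-membered aromatic ring, however, so no step speaks directly to the new group, and the direction is poorly defined.

With compound 3 already lowest at 27.5 nM, a small rise is more likely than a further fall in this assay, with a size similar to the largest step seen. The expected step is a 1.6-fold higher number from compound 3 to compound 4 (0.21 log units; within the scatter). For compound 4 the estimated value is 45 nM, with an expected range of 13 nM to 150 nM.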

Compound 4, concentration for 50% growth inhibition: 62 nM
Beside the measured number, compound 4's estimate is 1.4-fold (0.14 log units) below it; low and high end bracket the measured number.
By their numbers in this assay, from the lowest: compound 3; then compounds 4, 1 and 2 (each within the scatter of the next, the first and the last beyond it).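

In this assay, the first five-membered aromatic ring at this place, a saturated chain carbon bound to an aromatic nitrogen, gives a number that the pyridin-3-yl group cannot be told apart from (a 1.2-fold lower number from compound 1 to compound 4 (0.09 log units; within the scatter)), and the same ring clearly improves on the pyridin-4-yl group (a 2.2-fold lower number from compound 2 to compound 4 (0.34 log units; beyond the scatter)). Moving from 7 to 10 heavy atoms in this group therefore leaves the series in the range of the pyridine members, but the 6-methylpyridin-2-yl group keeps its lead (a 2.3-fold higher number from compound 3 to compound 4 (0.35 log units; beyond the scatter)), and of the four compounds only the one carrying that group is beyond the scatter of all the others. Nothing available explains these differences.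

On these data alone, the pyrazole appears only with its ethyl and isopropyl groups together, so the share of each in the result stays unknown, and a pyrazol-3-yl ring carrying only a methyl group would be needed to separate them. Also open, as far as these compounds go, is whether a saturated ring such as piperidin-4-yl, or an amine on the chain, would be tolerated at this place, since all four compounds keep an aromatic ring there.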